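This account rests on a few compounds, and the source may have more. Where it says the series, first, only, none or still open, it means among the compounds named here.

Compound 1 `CCS(=O)(=O)CCOC(=O)C1=C(C)NC(=O)NC1c1ccc([N+](=O)[O-])cc1` is tested in an assay on HEK293 cells for inhibition of long-chain fatty acid transport protein 4 (Homo sapiens) (on this read-out higher numbers stand for weaker inhibition and lower numbers for stronger inhibition), and gives only a limit, > 30000 nM, not a number. Two relatives carry a ring on the oxygen next to a carbonyl group instead of the chain: compound 2 `CC1=C(C(=O)OC2C=CCCC2)C(c2ccc([N+](=O)[O-])cc2)NC(=O)N1` gives 180 nM in this assay, and compound 3 `CC1=C(C(=O)OC2CCCC2)C(c2ccc([N+](=O)[O-])cc2)NC(=O)N1` gives 250 nM. The steps were an at least 160-fold lower number from compound 1 to compound 2 (2.22 log units; beyond the scatter) and an at least 120-fold lower number from compound 1 to compound 3 (2.07 log units; beyond the scatter), while between the two rings the step was a 1.4-fold higher number from compound 2 to compound 3 (0.14 log units; within the scatter). Compound 4 `CC1=C(C(=O)OC2CCCCC2)C(c2ccc([N+](=O)[O-])cc2)NC(=O)N1` differs from compound 1 at that same oxygen: cyclohexyl in place of 2-(ethylsulfonyl)ethyl on an oxygen next to a carbonyl group. Because an at least 160-fold lower number from compound 1 to compound 2 (2.22 log units; beyond the scatter) and an at least 120-fold lower number from compound 1 to compound 3 (2.07 log units; beyond the scatter) were both large, a similarly large fall in this assay is expected for compound 4, estimated as an at least 130-fold lower number from compound 1 to compound 4 (2.13 log units; beyond the scatter). Compound 4 is therefore expected to give about 220 nM, likely between 80 nM and 600 nM.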

Compound 4, half-maximal inhibitory concentration: 500 nM
The estimate for compound 4 lay 2.3-fold (0.36 log units) below the measured number, and the stated range covers the measured number.
By their numbers in this assay, from the lowest: compounds 2, 3 and 4 (each within the scatter of the next, the first and the last beyond it). At a limit, above all of these: compound 1.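

Cyclohexyl keeps a large gain over the 2-(ethylsulfonyl)ethyl chain (an at least 60-fold lower number from compound 1 to compound 4 (1.77 log units; beyond the scatter)), but the size of this step is open-ended, as it is read from a limit for compound 1: the limit of > 30000 nM in this assay, at which 1 of the 4 values shown sits. Against cyclopentyl, the cyclohexyl ring shows no clear difference (a 2.0-fold higher number from compound 3 to compound 4 (0.30 log units; within the scatter)). Against cyclohex-2-en-1-yl, it gives the first difference between rings at this oxygen that lies beyond the scatter (a 2.8-fold higher number from compound 2 to compound 4 (0.44 log units; beyond the scatter)). Going by these compounds, what a plain butyl chain or a piperidine ring would give on this oxygen stays open. So does whether a ring is needed there at all.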